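Chloro to dimethylamino on two cores

The source may report more compounds than this note shows. Statements on the series, on what has been measured and on what is new or still open speak of the compounds shown alone.

Compound 2 `OC[C@H]1O[C@@H](n2cnc3c(Cl)nccc32)C[C@@H]1O` and compound 1 `CN(C)c1nccc2c1ncn2[C@H]1C[C@H](O)[C@@H](CO)O1` share one core; compound 3 `OC[C@H]1OC(n2cnc3c(Cl)nccc32)[C@H](O)[C@@H]1O` carries a chloro on a second core, and the difference between the two cores is not broken down here. In a functional assay (Homo sapiens) for inhibition of Nucleic Acid, tested at 100 uM (on this read-out higher numbers stand for more inhibition at the one concentration tested (going by the name of the read-out) and lower numbers for less inhibition), compound 2 gives 5%, compound 1 gives 0% and compound 3 gives 76%, so compound 3 stands highest of the three, beyond the scatter from both others. The change dimethylamino in place of chloro on an aromatic carbon gave a number 5 percentage points lower from compound 2 to compound 1 (within the scatter), but both values sit near the floor of the read-out, so the swap is barely tested. Compound 4 `CN(C)c1nccc2c1ncn2C1O[C@H](CO)[C@@H](O)[C@H]1O` applies the same change, (dimethylamino in place of chloro on an aromatic carbon), to compound 3, which at 76% leaves room for a fall. For compound 4 the step is expected to be a number 21 percentage points lower from compound 3 to compound 4 (beyond the scatter), with wide uncertainty. That uncertainty exists because compound 2 gave 5% and compound 1 gave 0%, too low to show the swap's size. Compound 4 is estimated at 55%, between 15% and 85%.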

Compound 4, a percentage reported as inhibition, at one concentration (the size of the read-out at that concentration, not a potency): 0%
Beside the measured number, compound 4's estimate is 55 percentage points above it; measured number below the stated range.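

In this assay, dimethylamino in place of chloro on an aromatic carbon gave a number 76 percentage points lower from compound 3 to compound 4 (beyond the scatter) and so took the read-out to its floor on the second core. The size of the step did not carry from one core to the other: the same change on two cores in this assay, a number 5 percentage points lower (within the scatter) from compound 2 to compound 1 and a number 76 percentage points lower (beyond the scatter) from compound 3 to compound 4, 71 percentage points apart, beyond the scatter of two such steps. With compound 2 at 5% there was almost no inhibition left to lose, so the pair on the first core could not have shown a large fall, and these two pairs do not show that the cores respond differently to the change.

Open, from the compounds shown here alone, is whether any other replacement for chloro at this place, such as a primary amine or methoxy, keeps part of the inhibition seen for compound 3.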